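The source may hold more compounds than are shown below. What is called first, only, known or untested is meant among the compounds shown, and "the series" means these compounds.

Measured so far: compound 1 `Cc1ccc(=O)n(CCCCCC(=N)S)n1` with 36.6% in a functional assay on the whole organism (stomach) for inhibition, with Rattus norvegicus as the target, at a dose of 100 mg/kg by the intraduodenal route (a higher number here means more inhibition at the dose given (going by the name of the read-out), a lower number less inhibition), and compound 2 `N=C(S)CCCCCCn1nc(-c2ccccc2)ccc1=O` with 33.9% in the same assay.

For the measured compounds named here, only two compounds have been measured, and their two numbers lie within the scatter of each other, so compound 2 cannot be separated from compound 1 on these readings; the two share a core and differ in the group on that core and in the length of the chain that carries the group at its end.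

The next compound, compound 3 `N=C(S)CCCCCn1nc(-c2ccccc2)ccc1=O`, keeps the core of compound 2 and differs from it in one place: a group of 3 heavy atoms (1 carbon, 1 nitrogen, 1 sulfur; no ring) in place of a group of 4 heavy atoms (2 carbon, 1 nitrogen, 1 sulfur; no ring), on a saturated chain carbon, five bonds along the chain from an aromatic nitrogen. Going by the values given here, nothing measured so far isolates the effect of such a change in chain length on this core.

Compound 1, whose chain is as long as that of compound 3, gives a number within the scatter of compound 2, so no step beyond the scatter is expected here. The step of a number 1.1 percentage points higher from compound 2 to compound 3 (within the scatter) is expected to be small. Compound 3 is expected to give 35%, within a range from 20% to 50%.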

Compound 3, a percentage reported as inhibition, in the whole organism at one dose (the size of the read-out at that dose, not a potency): 91.4%
Compound 3: the middle estimate sits 56.4 percentage points below what was measured, and the stated range ends below it.
By their numbers in this assay, from the lowest: compounds 2 and 1 (each within the scatter of the next); then compound 3.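

In this assay the chain end proves highly sensitive on this core: a group of 3 heavy atoms (1 carbon, 1 nitrogen, 1 sulfur; no ring) in place of a group of 4 heavy atoms (2 carbon, 1 nitrogen, 1 sulfur; no ring), on a saturated chain carbon, five bonds along the chain from an aromatic nitrogen, gives a number 57.5 percentage points higher from compound 2 to compound 3 (beyond the scatter) and so separates two chain lengths that the earlier pair gave no means of telling apart. The group on the core also counts at this chain length, since phenyl in place of methyl on an aromatic carbon gives a number 54.8 percentage points higher from compound 1 to compound 3 (beyond the scatter) and, among these three compounds, the high reading appears only where phenyl and the shorter chain occur together. Nothing available on these compounds accounts for either step.

The compounds shown leave open how methyl behaves on the longer chain of compound 2, and whether a still shorter chain or a chlorine on the phenyl would keep the reading of compound 3. With a single dose in hand, they also leave open how the reading of compound 3 would change at other doses.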